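A few compounds are considered here, and "the series" means these few. Any claim that something is new, unique, unknown or untested is made for them only; others in the source may bear on it.

Of the compounds shown here, three have been measured in a functional assay on HCT-116 cells (Homo sapiens) for cytotoxicity, read by MTT assay, with a stated time of 48 h (on this read-out higher numbers stand for weaker inhibition of growth and lower numbers for stronger inhibition of growth), and a fourth awaits a number. Compound 1 `COc1cc2ncn([C@@H]3O[C@H](CO)[C@@H](O)[C@H]3O)c2cc1OC` carries a sugar on the shared core and gives only a limit, > 100000 nM, in this assay (the limit of > 100000 nM in this assay, at which 1 of the 3 values shown sits). Compound 2 `Cn1c(C(F)(F)F)nc2cc(Cl)c(Cl)cc21` bears a methyl on the aromatic nitrogen and gives 56000 nM in this assay. Compound 3 `O=[N+]([O-])c1ccccc1Cn1c(C(F)(F)F)nc2cc(Cl)c(Cl)cc21` carries a nitrobenzyl group on the same nitrogen and gives 5900 nM in this assay. Among the two real numbers, compound 2 stands at the higher one, and the gap down to compound 3 lies beyond the usual scatter; with only two such numbers, no wider pattern can be claimed.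

Compound 4 `FC(F)(F)c1nc2cc(Cl)c(Cl)cc2n1C1CCCC1` has not yet been measured. It differs from compound 2 in one place: cyclopentyl in place of methyl on an aromatic nitrogen. Among the compounds with values here, the only comparison available is that the larger nitrobenzyl group of compound 3 gave a lower number than the methyl of compound 2. Within the data shown here, a cyclopentyl is also larger than methyl, so a move in the same direction, of moderate size, is expected in this assay, though the one comparison is a thin base. Compound 4 is thus expected to give about 15000 nM, within a range from 4000 nM to 50000 nM. The expected step is a 3.7-fold lower number from compound 2 to compound 4 (0.57 log units; beyond the scatter).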

Compound 4, concentration for 50% growth inhibition: 22000 nM
Compound 4: the middle estimate sits 1.5-fold (0.17 log units) below what was measured, and the stated range covers the measured number.
By their numbers in this assay, from the lowest: compound 3; then compound 4; then compound 2. At a limit, above all of these: compound 1.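

In this assay, the change from methyl to cyclopentyl on the aromatic nitrogen gives a 2.5-fold lower number from compound 2 to compound 4 (0.41 log units; beyond the scatter) and is a modest step. This shows that a lower number at this position does not depend on a nitro group or an aromatic ring in the incoming group, since a ring of carbon only, with no hydrogen-bond donors or acceptors, also moves the number down. The cyclopentyl does not go as far as the nitrobenzyl group, however: compound 4 gives 22000 nM while compound 3 gives 5900 nM, and nothing shown explains why the number moves with either group.

On these data alone, whether the number simply follows the size of the group on this nitrogen stays open, as methyl, cyclopentyl and nitrobenzyl differ in more than size alone. Also open, as far as these compounds go, is what a plain benzyl, a cyclohexyl, a longer chain or a group carrying an amine or a carboxylic acid would give at this position in this assay, and whether the nitro group of compound 3 matters at all.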